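Sugar acetates removed: cytotoxicity of a long-chain amide pair

The source may hold more compounds than are shown below. What is called first, only, known or untested is meant among the compounds shown, and "the series" means these compounds.

Compound 1 `CCCCCCCCCCCCCC(=O)Nc1nnc(S[C@@H]2O[C@H](COC(C)=O)[C@H](OC(C)=O)[C@H](OC(C)=O)[C@H]2OC(C)=O)s1` and compound 2 `CCCCCCCC/C=C\CCCCCCCCCCCC(=O)Nc1nnc(S[C@@H]2O[C@H](COC(C)=O)[C@H](OC(C)=O)[C@H](OC(C)=O)[C@H]2OC(C)=O)s1` share a core built on a protected sugar. In an ADME assay on CHO-K1 cells (Cricetulus griseus) for cytotoxicity, read by MTT assay, with a stated time of 24 h (on this read-out higher numbers stand for weaker inhibition and lower numbers for stronger inhibition), compound 1 gives 16300 nM and compound 2 gives 25200 nM. The change between them is dec-1-en-1-yl in place of ethyl on a saturated chain carbon, ten or more bonds along the chain from a carbonyl carbon, and it made a step of a 1.5-fold higher number from compound 1 to compound 2 (0.19 log units; within the scatter). Compound 3 `CCCCCCCCCCCCCC(=O)Nc1nnc(S[C@@H]2O[C@H](CO)[C@H](O)[C@H](O)[C@H]2O)s1` carries the free sugar instead; the difference between the two cores is not broken down here. In this assay compound 3 gives "not active" (no number reported), with no number reported for it. Compound 4 `CCCCCCCC/C=C\CCCCCCCCCCCC(=O)Nc1nnc(S[C@@H]2O[C@H](CO)[C@H](O)[C@H](O)[C@H]2O)s1` differs from compound 3 by dec-1-en-1-yl in place of ethyl on a saturated chain carbon, ten or more bonds along the chain from a carbonyl carbon, the same change as before. Since the earlier step of a 1.5-fold higher number from compound 1 to compound 2 (0.19 log units; within the scatter) was small, a similarly small step is expected here, so compound 4 is expected to stay without activity, with an estimated value of 60000 nM between 20000 nM and 200000 nM.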

Compound 4, half-maximal inhibitory concentration: "not active" (no number reported)
Compound 4 has no reported number here, and the estimate cannot be compared.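

Compound 3 and compound 4 are both reported as not active without a number, so no step can be read between them. How dec-1-en-1-yl in place of ethyl acts on the free sugar stays open, and no evidence here offers an explanation.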